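The source may hold more compounds than are shown below. What is called first, only, known or untested is meant among the compounds shown, and "the series" means these compounds.

In a functional assay on HCT-116 cells (Homo sapiens) for antiproliferative activity, read by MTT assay, with a stated time of 48 h (on this read-out lower numbers stand for stronger inhibition and higher numbers for weaker inhibition), compound 3 `Cc1ccccc1C(=O)Nc1cccc(/C=C/C(=O)c2nc3ccccc3[nH]2)c1` gives 1870 nM, the second highest of the three numbers shown; its nearest neighbour is compound 2 `O=C(Nc1cccc(/C=C/C(=O)c2nc3ccccc3[nH]2)c1)c1ccc(Br)cc1`, which gives 2230 nM, and its furthest is compound 1 `O=C(/C=C/c1cccc(NC(=O)c2ccccc2Cl)c1)c1nc2ccccc2[nH]1`, which gives 1280 nM. Compound 4 `O=C(Nc1cccc(/C=C/C(=O)c2nc3ccccc3[nH]2)c1)c1cccc(C(F)(F)F)c1` carries 3-(trifluoromethyl)phenyl in place of 2-methylphenyl on a carbonyl carbon. Among the compounds with values here, the steps that bear on this exchange of the aryl group on the carbonyl carbon are a 1.7-fold higher number from compound 1 to compound 2 (0.24 log units; within the scatter), a 1.2-fold lower number from compound 2 to compound 3 (0.08 log units; within the scatter) and a 1.5-fold higher number from compound 1 to compound 3 (0.16 log units; within the scatter), each within the scatter. Three different aryl groups on that carbonyl carbon have thus given numbers within the scatter of one another, so no step beyond the scatter is expected in this assay for compound 4. Compound 4 is estimated at 1800 nM, within 700 nM to 4500 nM, which means an expected step of a 1.0-fold lower number from compound 3 to compound 4 (0.02 log units; within the scatter).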

Compound 4, half-maximal inhibitory concentration: 3360 nM
For compound 4 the middle estimate is 1.9-fold (0.27 log units) below the measured one; low and high end bracket the measured number.
By their numbers in this assay, from the lowest: compounds 1, 3, 2 and 4 (each within the scatter of the next, the first and the last beyond it).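

In this assay the 3-(trifluoromethyl)phenyl group on the carbonyl carbon gives a 1.8-fold higher number from compound 3 to compound 4 (0.25 log units; within the scatter) and a 1.5-fold higher number from compound 2 to compound 4 (0.18 log units; within the scatter) as steps that stay within the scatter. Yet a 2.6-fold higher number from compound 1 to compound 4 (0.42 log units; beyond the scatter) is the first step at this position to lie beyond the scatter, though only modestly, so the aryl group here can register in this read-out. No measurement shown accounts for this step. In this assay, on these data alone, it remains open how an amine, a carboxylic acid or a longer chain would read in place of the aryl group on this carbonyl carbon.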